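The source may report more compounds than this note shows. Statements on the series, on what has been measured and on what is new or still open speak of the compounds shown alone.

In a functional assay on IGROV-1 cells (Homo sapiens) for inhibition, read by sulforhodamine B assay, with a stated time of 48 h (a lower number here means a stronger inhibitor of growth, a higher number a weaker inhibitor of growth), compound 1 `N#C/C(=C\c1c(-c2ccccc2)[nH]c2ccccc12)C(=O)c1ccccc1` gives 2500 nM, the lowest of the three numbers in hand. Compound 2 `COc1ccc2[nH]c(-c3ccccc3)c(C=C(C#N)C#N)c2c1` gives 8400 nM in this assay, and compound 3 `COc1ccc(-c2[nH]c3ccc(OC)cc3c2C=C(C#N)C#N)cc1` gives 5800 nM; both of these stand beyond the scatter from compound 1, compound 3 nearer and compound 2 further. Going by the values given here, the single measured step, a 1.4-fold lower number from compound 2 to compound 3 (0.16 log units; within the scatter), concerns methoxy in place of hydrogen on an aromatic carbon and leaves the chain untouched.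

Compound 4 `N#C/C(=C\c1c(-c2ccccc2)[nH]c2ccccc12)S(=O)(=O)c1ccccc1` differs from compound 1 by phenylsulfonyl in place of benzoyl on a double-bonded chain carbon bound to a double-bonded chain carbon and a triple-bonded carbon. Among the compounds with values here, no measured step touches this chain carbon or exchanges one chain substituent for another, so nothing among the compounds in hand indicates a direction for this assay. The working expectation is therefore a number close to that of compound 1, with a range widened to reflect the absence of a precedent. Compound 4 is expected to give about 3000 nM in this assay, between 800 nM and 12000 nM. For compound 4 the estimated step is a 1.2-fold higher number from compound 1 to compound 4 (0.08 log units; within the scatter), which is expected not to exceed the scatter.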

Compound 4, concentration for 50% growth inhibition: 3300 nM
Compound 4: middle estimate off by 1.1-fold (0.04 log units), on the low side; the range from low to high includes it.
By their numbers in this assay, from the lowest: compounds 1, 4, 3 and 2 (each within the scatter of the next, the first and the last beyond it).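

In this assay, phenylsulfonyl in place of benzoyl on a double-bonded chain carbon bound to a double-bonded chain carbon and a triple-bonded carbon gives a 1.3-fold higher number from compound 1 to compound 4 (0.12 log units; within the scatter), the only step shown at this chain carbon. This position therefore accepts the exchange of benzoyl for phenylsulfonyl with a difference that stays within the scatter, so the assay does not separate these two groups on the core of compound 1. Nothing available explains this result.

From the compounds shown here alone, whether the chain carbon tolerates a group without an aromatic ring, such as a carboxylic acid or an amine-bearing amide, remains open. Also open, going by these compounds, is whether methoxy on the core of compound 4 would give a step like the one within the scatter seen at a 1.4-fold lower number from compound 2 to compound 3 (0.16 log units; within the scatter).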